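A few compounds are considered here, and "the series" means these few. Any claim that something is new, unique, unknown or untested is made for them only; others in the source may bear on it.

Measured compounds:
compound 1 `C=CC(=O)Nc1cccc(Nc2nc(N/N=C/c3cn(Cc4ccccc4)c4ccccc34)ncc2Cl)c1` — 11000 nM
compound 2 `CN(C)C/C=C/C(=O)Nc1cccc(Nc2nc(N/N=C/c3ccc(F)cc3F)ncc2Cl)c1` — 2920 nM
compound 3 `CN(C)C/C=C/C(=O)Nc1cccc(Nc2nc(N/N=C/c3c[nH]c4ccccc34)ncc2Cl)c1` — 9680 nM

Among the compounds with values here, in an ADME assay on HT-29 cells (Homo sapiens) for inhibition, read by MTT assay, with a stated time of 72 h (on this read-out lower numbers stand for stronger inhibition and higher numbers for weaker inhibition), compound 3 stands second highest of the three numbers; compound 1 lies within the scatter of it, whereas the only single-point step, a 3.3-fold higher number from compound 2 to compound 3 (0.52 log units; beyond the scatter), is modest but beyond the scatter. Compound 4 `CN(C)C/C=C/C(=O)Nc1cccc(Nc2nc(N/N=C/c3cn(Cc4ccccc4)c4ccccc34)ncc2Cl)c1` differs from compound 3 by benzyl in place of hydrogen on an aromatic nitrogen. Within the data shown here, no measured step covers this change; the one step measured concerns a different position. Compound 1, which carries the same benzyl group on the aromatic nitrogen, gives 11000 nM, close to compound 3, so a step beyond the scatter is not expected, and the expected step is a 1.0-fold higher number from compound 3 to compound 4 (0.01 log units; within the scatter). Compound 4 is therefore estimated at 10000 nM, in a range from 4000 nM to 25000 nM.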

Compound 4, half-maximal inhibitory concentration: 2120 nM
Compound 4: the middle estimate sits 4.7-fold (0.67 log units) above what was measured; measured number outside the range, below it.
By their numbers in this assay, from the lowest: compounds 4 and 2 (each within the scatter of the next); then compounds 3 and 1 (each within the scatter of the next).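

In this assay, benzyl in place of hydrogen on the aromatic nitrogen gives a 4.6-fold lower number from compound 3 to compound 4 (0.66 log units; beyond the scatter), so this position can change the read-out when the 3-(dimethylamino)prop-1-en-1-yl group is present. With the benzyl kept, 3-(dimethylamino)prop-1-en-1-yl in place of vinyl on the carbonyl carbon gives a 5.2-fold lower number from compound 1 to compound 4 (0.72 log units; beyond the scatter), so the change at the carbonyl carbon matters too. Nothing available explains either step. As far as these compounds go, whether benzyl would give a similar step with vinyl on the carbonyl carbon stays open. Also open, from the compounds shown here alone, is how a methyl group, a longer alkyl chain or a fluorine-bearing benzyl would compare on that aromatic nitrogen.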